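Hydrogen for methyl on the amide nitrogen: permeability notes

This account rests on a few compounds, and the source may have more. Where it says the series, first, only, none or still open, it means among the compounds named here.

Three compounds share a 2-carbamoylpyridin-4-yl-type side chain on two related cores: compound 1 `CNC(=O)c1cc(Oc2ccc3sc(Nc4cccc(C(C)(C)C)c4)nc3c2)ccn1`, compound 2 `CNC(=O)c1cc(Oc2ccc3oc(Nc4cccc(C(C)C)c4)nc3c2)ccn1` and compound 3 `CC(C)c1cccc(Nc2nc3cc(Oc4ccnc(C(N)=O)c4)ccc3o2)c1`. In an ADME assay on Caco-2 cells (Homo sapiens) for permeability, in the apical to basolateral direction (a lower number here means that the compound crosses the layer more slowly, a higher number that the compound crosses the layer faster), compound 1 gives 10 10^-6 cm/s. In this assay compound 2 gives 10 10^-6 cm/s, and compound 3 gives 10 10^-6 cm/s.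

Compound 2 and compound 3 differ by hydrogen in place of methyl on an amide-type nitrogen, and the step is no change at the digits printed from compound 2 to compound 3 (within the scatter). Compound 1 stands level with compound 2 and compound 3 at the digits recorded; how the core of compound 1 differs from the core of compound 2 is not broken down here.

Compound 4 `CC(C)(C)c1cccc(Nc2nc3cc(Oc4ccnc(C(N)=O)c4)ccc3s2)c1` has not been measured in this assay. It differs from compound 1 by hydrogen in place of methyl on an amide-type nitrogen, the same change as from compound 2 to compound 3, at a place described in the same words. This change occurs twice among the compounds shown, once measured. Resting on that single pair, the step from compound 1 to compound 4 in this assay is expected to be no change at the digits printed from compound 1 to compound 4 (within the scatter), beside no change at the digits printed from compound 2 to compound 3 (within the scatter). Compound 4 is accordingly estimated at 10 10^-6 cm/s, with a likely range from 5 10^-6 cm/s to 20 10^-6 cm/s.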

Compound 4, apparent permeability: 10 10^-6 cm/s
For compound 4 middle estimate and measured number coincide at the digits printed; measured number inside the range.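

In this assay, hydrogen in place of methyl on the amide-type nitrogen of compound 1 gives no change at the digits printed from compound 1 to compound 4 (within the scatter). Set beside the earlier pair, the change reads alike on the two cores: the same change on two cores in this assay, no change at the digits printed (within the scatter) from compound 2 to compound 3 and no change at the digits printed (within the scatter) from compound 1 to compound 4, 1.0-fold (0.00 log units) apart, within the scatter of two such steps

So, within these two pairs, the step from methylcarbamoyl to carbamoyl carries from one core to the other without a visible difference in this read-out, but two pairs are a narrow base, and nothing here shows that the same would hold on a further core or what the core alone contributes.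

The compounds shown leave open whether an ethyl group or a longer chain on the amide nitrogen, or a carboxylic acid in place of the carbamoyl group, would stay level with these four compounds in this assay. Also open, from the compounds shown here alone, is how the same change from methyl to hydrogen reads in any measure other than this permeability read-out.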